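Moving the hydroxyl on a biaryl pyridine: cytotoxicity outlook

The source may hold more compounds than are shown below. What is called first, only, known or untested is meant among the compounds shown, and "the series" means these compounds.

Measured compounds:
compound 1, `Oc1ccc(-c2cc(-c3cccs3)nc(-c3ccccc3Cl)c2)cc1`: 5220 nM
compound 2, `Oc1ccc(-c2cc(-c3ccco3)nc(-c3ccccc3Cl)c2)cc1`: 4310 nM

In an ADME assay on HEK293 cells (Homo sapiens) for cytotoxicity, read by CCK-8 assay and cell counting, with a stated time of 2 days (on this read-out higher numbers stand for weaker inhibition and lower numbers for stronger inhibition), compound 1 gives 5220 nM, the highest of the two numbers, although the step of a 1.2-fold lower number from compound 1 to compound 2 (0.08 log units; within the scatter) is within the scatter. Compound 3, `Oc1cccc(-c2cc(-c3cccs3)nc(-c3ccccc3Cl)c2)c1`, differs from compound 1 by 3-hydroxyphenyl in place of 4-hydroxyphenyl on an aromatic carbon. Among the measured compounds shown here, no measured step touches the hydroxyphenyl group, so nothing among the measured steps bears on this change; the expectation is no step beyond the scatter. Compound 3 is therefore expected to give 5000 nM, within 2000 nM to 13000 nM, a step of a 1.0-fold lower number from compound 1 to compound 3 (0.02 log units; within the scatter).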

Compound 3, half-maximal inhibitory concentration: 2600 nM
The estimate for compound 3 lay 1.9-fold (0.28 log units) above the measured number; measured number inside the range.
By their numbers in this assay, from the lowest: compounds 3, 2 and 1 (each within the scatter of the next).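

In this assay, 3-hydroxyphenyl in place of 4-hydroxyphenyl, on the carbon opposite the ring nitrogen, gives a 2.0-fold lower number from compound 1 to compound 3 (0.30 log units; within the scatter). Among the compounds shown here, this is the first reading at this position, and moving the hydroxyl within the ring does not separate the two compounds beyond the scatter. Nothing available explains this result.

From the compounds shown here alone, it remains open whether a methoxy group or an amine in place of the hydroxyl would give a step beyond the scatter. Going by these compounds, whether 3-hydroxyphenyl gives a similar result alongside the furan-2-yl group of compound 2 also remains open.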